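Swapping the Amide Substituent: An Outlook for Compound 4

The compounds below may be only part of what the source reports. "The series", "measured", "known", "first", "only" and "open" are said of these compounds alone.

Compound 1, `O=C(CN1CCC(c2cccc[n+]2[O-])CC1)NC1CCCCC1`: 58%
Compound 2, `O=C(CN1CCC(c2cccc[n+]2[O-])CC1)Nc1cc(Cl)cc(Cl)c1`: 68%
Compound 3, `CSc1cccc(NC(=O)CN2CCC(c3cccc[n+]3[O-])CC2)c1`: 56%

All three were measured in a functional assay on HEK293 cells for agonist activity at D(4) dopamine receptor (Homo sapiens), read by FLIPR; a lower number here means a smaller maximal response, a higher number a larger maximal response. Compound 3 gives the lowest of the three numbers, though only compound 2 stands beyond the scatter from it, as seen in a number 12 percentage points lower from compound 2 to compound 3 (beyond the scatter); compound 1 is within it, as a number 2 percentage points lower from compound 1 to compound 3 (within the scatter) shows. Compound 4, `Cc1ccc(Cl)cc1NC(=O)CN1CCC(c2cccc[n+]2[O-])CC1`, differs from compound 3 in one place: 5-chloro-2-methylphenyl in place of 3-(methylsulfanyl)phenyl on an amide-type nitrogen. Every measured step varies this same amide-type nitrogen substituent: a number 10 percentage points higher from compound 1 to compound 2 (within the scatter) and a number 2 percentage points lower from compound 1 to compound 3 (within the scatter) stayed within the scatter, while a number 12 percentage points lower from compound 2 to compound 3 (beyond the scatter) was modest. The group entering compound 4 carries chlorine, as in compound 2 with its 68%, so a small rise, a number 7 percentage points higher from compound 3 to compound 4 (within the scatter), is expected, near the edge of the scatter. Compound 4 is estimated at 63%, ranging from 51% to 75%.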

Compound 4, largest response reached (reported as efficacy), in percent of the reference or control that the assay uses: 58%
Compound 4: middle estimate off by 5 percentage points, on the high side; measured number inside the range.
By their numbers in this assay, from the lowest: compounds 3, 1, 4 and 2 (each within the scatter of the next, the first and the last beyond it).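

With 5-chloro-2-methylphenyl on the amide-type nitrogen, this assay gives a number 2 percentage points higher from compound 3 to compound 4 (within the scatter), a number 10 percentage points lower from compound 2 to compound 4 (within the scatter) and no change at the digits printed from compound 1 to compound 4 (within the scatter). Among these compounds, compound 4 therefore cannot be told apart from any of the other three compounds, even though it shares chlorine with compound 2, so a chlorine-bearing aryl group at this position does not by itself track with the one step beyond the scatter. Nothing available here explains these results. On these data alone, it remains open whether a benzyl group, a 4-aminophenyl group or a 4-carboxyphenyl group on this nitrogen would produce a step beyond the scatter.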